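From Chloro to Bromo on the Pendant Phenyl

The compounds below may be only part of what the source reports. "The series", "measured", "known", "first", "only" and "open" are said of these compounds alone.

Compound 1 `CNC(=O)c1cc(Oc2ccc(NC(=O)c3cc4cccnc4n(-c4ccccc4)c3=O)cc2)ccn1`: 320 nM
Compound 2 `CNC(=O)c1cc(Oc2ccc(NC(=O)c3cc4cccnc4n(-c4ccc(F)cc4)c3=O)cc2)ccn1`: 210 nM
Compound 3 `CNC(=O)c1cc(Oc2ccc(NC(=O)c3cc4cccnc4n(-c4ccc(Cl)cc4)c3=O)cc2)ccn1`: "not determined" (no result reported)

These numbers come from a functional assay on NCI-H460 cells (Homo sapiens) for antiproliferative activity, read by MTT assay, with a stated time of 72 h; on this read-out lower numbers stand for stronger inhibition and higher numbers for weaker inhibition. Compound 3 stands without a number of its own: no result was reported for it in this assay, so there is nothing to place it by directly. Compound 4 `CNC(=O)c1cc(Oc2ccc(NC(=O)c3cc4cccnc4n(-c4ccc(Br)cc4)c3=O)cc2)ccn1` differs from compound 3 by bromo in place of chloro on an aromatic carbon. For the measured compounds named here, only one measured step concerns a change on this same ring: a 1.5-fold lower number from compound 1 to compound 2 (0.18 log units; within the scatter), an exchange of one substituent for another that stayed within the scatter. That step does not involve chloro or bromo, so it bears only loosely on the present change, but it points to a small step in this assay, with no direction beyond the scatter. Compound 4 is therefore expected to give about 250 nM, between 100 nM and 650 nM.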

Compound 4, half-maximal inhibitory concentration: 3710 nM
Beside the measured number, compound 4's estimate is 15-fold (1.17 log units) below it; the whole stated range lies below it.
By their numbers in this assay, from the lowest: compounds 2 and 1 (each within the scatter of the next); then compound 4.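

The step from hydrogen to fluoro left open whether this position, para to a large group, responds to change at all, and bromo answers that: in this assay it gives an 18-fold higher number from compound 2 to compound 4 (1.25 log units; beyond the scatter) and a 12-fold higher number from compound 1 to compound 4 (1.06 log units; beyond the scatter) and so moves the number well beyond the scatter. A single atom at this place on the ring can therefore matter greatly. Nothing available explains why bromo behaves this way.

Going by these compounds, with no number for compound 3, it stays open whether chloro already raises the value or only bromo does. On these data alone, how methoxy or an amine on this carbon would read also remains unknown.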